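This account rests on a few compounds, and the source may have more. Where it says the series, first, only, none or still open, it means among the compounds named here.

Compound 3 `COc1ccc(-c2cc3c(C)nc(N)nc3n([C@H]3CC[C@@H](O)CC3)c2=O)cn1` gives only a limit in an ADME assay (liver) for metabolic stability, with Liver microsome (Homo sapiens) as the target, using microsomes; on this read-out lower numbers stand for lower hepatic extraction and higher numbers for higher hepatic extraction: for compound 3 the read-out is < 0.26, a limit of the assay and not a number. Its mirror image, compound 2 `COc1ccc(-c2cc3c(C)nc(N)nc3n([C@H]3CC[C@H](O)CC3)c2=O)cn1`, likewise returns a limit in this assay, < 0.25. The step that the two limits leave unreadable from compound 2 to compound 3 is thus unreadable, since both values are limits the limit of < 0.25 in this assay, at which 1 of the 3 values shown sits, the limit of < 0.26 in this assay, at which 1 of the 3 values shown sits, and the pair differs only in configuration (the fact that compounds 2 and 3 differ only in the configuration as drawn). Differing from compound 3 in several places, compound 1 `CNc1nc(C)c2cc(-c3cccc(CO)c3)c(=O)n(C3CCCC3)c2n1` gives 0.68 in this assay. Compound 4 `COc1ccc(-c2cc3c(C)nc(N)nc3n(C3CCOCC3)c2=O)cn1` differs from compound 3 by oxan-4-yl in place of 4-hydroxycyclohexyl on an aromatic nitrogen. Among the compounds with values here, no measured step covers this change, so any expectation rests on the values alone. Compound 4 is expected at 0.4, with a range of 0.2 to 0.62. This estimate implies a step a number at least 0.14 higher from compound 3 to compound 4 (beyond the scatter) in this assay.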

Compound 4, hepatic extraction ratio: < 0.26
Compound 4 gave a limit, no number; the forecaster's own chance of this, stated with the estimate: 25%; at least 0.14 between middle value and limit.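

Within the data shown here, compound 2, compound 3 and compound 4 all give limits and not numbers in this assay, and no step among them can be read. The compounds shown leave open how far oxan-4-yl and 4-hydroxycyclohexyl differ on this read-out.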